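Swapping One Halogen on Compound 1: Expected Cytotoxicity

The source may hold more compounds than are shown below. What is called first, only, known or untested is meant among the compounds shown, and "the series" means these compounds.

Measured compounds:
compound 1, `CC/C(=C\c1ccc(Cl)cc1)C(=O)/C=C/c1ccc(Cl)cc1`, 28300 nM
compound 2, `COc1ccc(/C=C(\C)C(=O)/C=C/c2ccc(Cl)cc2)cc1`, 87000 nM

Of the compounds shown here, two have been measured in an ADME assay on Vero cells (Chlorocebus sabaeus) for cytotoxicity, read by MTT assay, with a stated time of 72 h; on this read-out lower numbers stand for higher toxicity in this test and higher numbers for lower toxicity in this test. Compound 1 gives 28300 nM, the lowest of the two numbers. Compound 2 gives 87000 nM, a number that lies beyond the scatter above compound 1, so compound 1 is the more toxic of the pair in this assay. The two differ in several places at once, so the gap between them is simply what the two values show and cannot be tied to a single change.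

The unmeasured compound 3, `CC/C(=C\c1ccc(Cl)cc1)C(=O)/C=C/c1ccc(Br)cc1`, differs from compound 1 in one place: bromo in place of chloro on an aromatic carbon. The change leaves one ring-bound chlorine and brings in one bromine in its place, with nothing gained or lost in donors, acceptors or charge.

Going by the values given here, no step between measured compounds isolates this kind of exchange, so the expectation rests on compound 1 alone. The step of a 1.2-fold lower number from compound 1 to compound 3 (0.09 log units; within the scatter) is expected to be small, staying within the scatter of repeated measurements. Compound 3 is therefore estimated at 23000 nM, with a range from 10000 nM to 50000 nM.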

Compound 3, half-maximal cytotoxic concentration: 29400 nM
The estimate for compound 3 lay 1.3-fold (0.11 log units) below the measured number; low and high end bracket the measured number.
By their numbers in this assay, from the lowest: compounds 1 and 3 (each within the scatter of the next); then compound 2.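

In this assay bromo in place of chloro on this aromatic carbon gives a 1.0-fold higher number from compound 1 to compound 3 (0.02 log units; within the scatter) and so stays within the scatter of repeated measurements. Going by these compounds alone, this is the first reading in the set that belongs to one place alone, as the earlier pair differed in several places at once and could not be tied to any single change. It shows that, on the core of compound 1, 4-chlorophenyl and 4-bromophenyl cannot be told apart in this test, and nothing measured alongside these numbers offers an explanation for that sameness.

The compounds shown leave open whether a group of another kind on this same aromatic carbon, such as an amine, a carboxylic acid or a nitrile, would move the number beyond the scatter or leave it where the two halogens stand. They also leave open whether the same exchange would read alike on the chlorine that remains in compound 3, or on a different core such as that of compound 2.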